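Swapping ethynyl for furan-3-yl on a nucleoside core

The source may report more compounds than this note shows. Statements on the series, on what has been measured and on what is new or still open speak of the compounds shown alone.

Compound 2 `C#Cc1cn([C@@H]2O[C@H](CO)[C@@H](O)[C@H]2O)c2ncnc(N(C)C)c12` carries an ethynyl group on its fused core; in a functional assay on K562 cells (Homo sapiens), read by MTT assay, with a stated time of 72 h (on this read-out lower numbers stand for stronger inhibition and higher numbers for weaker inhibition), compound 2 gives 110 nM. Compound 1 `CN(C)c1ncnc2c1c(-c1ccoc1)cn2[C@@H]1O[C@H](CO)[C@@H](O)[C@H]1O` differs by furan-3-yl in place of ethynyl on an aromatic carbon; in this assay compound 1 gives 1540 nM. That exchange produced a 14-fold higher number from compound 2 to compound 1 (1.15 log units; beyond the scatter), a marked weakening. Compound 3 `C#Cc1cn([C@@H]2O[C@H](CO)[C@@H](O)[C@H]2O)c2nc(N)nc(OC)c12` keeps the ethynyl group on a different core; the difference between the two cores is not broken down here. In this assay compound 3 reaches only the limit > 20000 nM, so no number is known for it (the limit of > 20000 nM in this assay, at which 1 of the 3 values shown sits). Compound 4 `COc1nc(N)nc2c1c(-c1ccoc1)cn2[C@@H]1O[C@H](CO)[C@@H](O)[C@H]1O` differs from compound 3 by furan-3-yl in place of ethynyl on an aromatic carbon, the same change as before. Because the same change earlier gave a 14-fold higher number from compound 2 to compound 1 (1.15 log units; beyond the scatter), the expected step is a step that the limit leaves unreadable from compound 3 to compound 4. Compound 4 is therefore expected to give about 40000 nM, most likely again reported only as a limit.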

Compound 4, half-maximal inhibitory concentration: > 20000 nM
Compound 4: a limit, no number; the forecaster's own chance of this, stated with the estimate: 85%; the middle value does not contradict the limit.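

Compound 3 and compound 4 both end at a limit rather than a number, so the step between them cannot be read: the limit of > 20000 nM in this assay, at which 2 of the 4 values shown sit.

As far as these compounds go, whether furan-3-yl in place of ethynyl costs as much on the core of compound 3 as on the core of compound 2 stays open.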